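Methylating the Aromatic Hydroxy: Compound 3 to Compound 4

The source may hold more compounds than are shown below. What is called first, only, known or untested is meant among the compounds shown, and "the series" means these compounds.

The measured compounds and their values:
Compound 1, `COc1c(Br)cc(Br)cc1C(=O)Nc1ccccc1`, in an assay for inhibition of HSP60/HSP10 (Homo sapiens), with a stated time of 60 min (a lower number here means a stronger inhibitor, a higher number a weaker inhibitor), gives > 100000 nM, which is a limit of the assay and not a number.
Compound 2, `O=C(Nc1ccccc1)c1cc(Br)cc(Br)c1O`, in this assay gives 63000 nM.
Compound 3, `O=C(Nc1cccc(Cl)c1)c1cccc(Br)c1O`, in this assay gives > 100000 nM, again a limit of the assay and not a number.

Going by the values given here, the one step that can be measured runs from compound 2 to compound 1: methyl in place of hydrogen on an oxygen on an aromatic ring. It gives an at least 1.5-fold higher number from compound 2 to compound 1 (0.20 log units; that floor lies within the scatter). Because compound 1 sits at the limit of > 100000 nM in this assay, at which 2 of the 3 values shown sit, the step is known only as a floor.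

Compound 4, `COc1c(Br)cccc1C(=O)Nc1cccc(Cl)c1`, is not yet measured. It differs from compound 3 by the same kind of change: methyl in place of hydrogen on an oxygen on an aromatic ring. The two place lines read the same word for word. How the core of compound 3 differs from that of compound 2 is not broken down here.

Compound 3 already sits at the limit of this assay, so compound 4 is expected to start from a limit and, if anything, to move the same way as compound 1. The step from compound 3 to compound 4 is therefore estimated at a step that the limit leaves unreadable from compound 3 to compound 4, resting on the floor seen in an at least 1.5-fold higher number from compound 2 to compound 1 (0.20 log units; that floor lies within the scatter). Compound 4 is expected to give about 300000 nM in this assay, between 100000 nM and 1000000 nM, and most likely it will be reported only as a limit.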

Compound 4, half-maximal inhibitory concentration: > 100000 nM
Compound 4 was reported as a limit (the forecaster's own chance of this, stated with the estimate: 90%); the middle value is on the limit's open side.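

In this assay compound 4 gives > 100000 nM, which is a limit of the assay and not a number. Compound 3 also stands at a limit, so no step can be read between compound 3 and compound 4, because neither has a number: the limit of > 100000 nM in this assay, at which 3 of the 4 values shown sit.

The compounds shown leave open how large the change from hydroxy to methoxy actually is on either core.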